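Ether Side Chain in Place of Butyl(ethyl)amino

The compounds below may be only part of what the source reports. "The series", "measured", "known", "first", "only" and "open" are said of these compounds alone.

Compound 1 `CCCCN(CC)c1nc(C)nc2c1nnn2-c1ccc(C(C)C)cc1Br` gives 7.5 nM in an in vitro assay on 293-EBNA cells for binding affinity to corticotropin-releasing factor receptor 1 (Homo sapiens) (a lower number here means a stronger inhibitor, a higher number a weaker inhibitor), the lowest of the two numbers at hand; its nearest neighbour is compound 2 `CCCCN(CC)c1nc(C)nc2c1nnn2-c1ccc(S(C)(=O)=O)cc1Br`, which gives 100 nM. For the measured compounds named here, the one measured step, a 13-fold higher number from compound 1 to compound 2 (1.12 log units; beyond the scatter), is a methylsulfonyl in place of isopropyl on an aromatic carbon and leaves the butyl(ethyl)amino untouched. Compound 3 `CCOCC(COCC)Oc1nc(C)nc2c1nnn2-c1ccc(C(C)C)cc1Br` differs from compound 1 instead by a group of 10 heavy atoms (7 carbon, 3 oxygen; no ring) in place of a group of 7 heavy atoms (6 carbon, 1 nitrogen; no ring), on an aromatic carbon. Going by the values given here, no measured step covers this change, so the expectation rests on the shared core and the isopropyl and bromine retained from compound 1 alone, and no step beyond the scatter is expected in either direction. Compound 3 is therefore estimated at 15 nM, with a range from 4 nM to 60 nM, which corresponds to an expected step of a 2.0-fold higher number from compound 1 to compound 3 (0.30 log units; within the scatter).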

Compound 3, inhibition constant: 39.7 nM
Beside the measured number, compound 3's estimate is 2.6-fold (0.42 log units) below it; the range from low to high includes it.
By their numbers in this assay, from the lowest: compound 1; then compound 3; then compound 2.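

In this assay, exchanging butyl(ethyl)amino on the aromatic carbon next to the ring nitrogen for the group of 10 heavy atoms gives a 5.3-fold higher number from compound 1 to compound 3 (0.72 log units; beyond the scatter), so with the isopropyl and bromine kept, butyl(ethyl)amino is the better of the two groups here. The position nevertheless accepts a side chain with no nitrogen and 3 hydrogen-bond acceptors in place of 1, and compound 3 still gives 39.7 nM. Nothing at hand accounts for the loss.

The change replaces the linking atom and the chain at once, so the compounds shown do not tell which of the two carries the step. A butoxy group, or bis(2-methoxyethyl)amino, would keep one of them and alter the other.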